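Bromination of a Fused Ring in Two Related Series

The source may report more compounds than this note shows. Statements on the series, on what has been measured and on what is new or still open speak of the compounds shown alone.

The three measured compounds, all tested in a functional assay on cells (Cancer cell lines, Homo sapiens) for cytotoxicity, read by sulforhodamine B assay, with a stated time of 48 h; on this read-out higher numbers stand for weaker inhibition of growth and lower numbers for stronger inhibition of growth:
Compound 1 `O=C1N=C(N2N=C(c3ccccc3)CC2c2ccccc2O)S/C1=C1/C(=O)Nc2ccccc21` gives 2030 nM.
Compound 2 `O=C1N=C(N2N=C(c3ccccc3)CC2c2ccccc2O)S/C1=C1/C(=O)Nc2ccc(Br)cc21` gives 240 nM.
Compound 3 `COc1ccc(C2=NN(C3=NC(=O)/C(=C4\C(=O)Nc5ccccc54)S3)C(c3ccc(Cl)cc3)C2)cc1` gives 92400 nM.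

Compound 2 differs from compound 1 only by bromo in place of hydrogen on an aromatic carbon, and that change gave an 8.5-fold lower number from compound 1 to compound 2 (0.93 log units; beyond the scatter). Compound 3 has a different core from compound 1; the difference between the two cores is not broken down here, but in this assay compound 3 stands far weaker than both compound 1 and compound 2.

Compound 4 `COc1ccc(C2=NN(C3=NC(=O)/C(=C4\C(=O)Nc5ccc(Br)cc54)S3)C(c3ccc(Cl)cc3)C2)cc1` has not yet been measured. It differs from compound 3 by bromo in place of hydrogen on an aromatic carbon, the same change that took compound 1 to compound 2. For the measured compounds named here, because only the single step of an 8.5-fold lower number from compound 1 to compound 2 (0.93 log units; beyond the scatter) is known for this change, and it was measured on a core unlike that of compound 3, the expected step from compound 3 to compound 4 is taken as similar in direction but uncertain in size, a 7.7-fold lower number from compound 3 to compound 4 (0.89 log units; beyond the scatter). On that basis compound 4 is estimated to give 12000 nM in this assay, with a plausible range from 3000 nM to 50000 nM.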

Compound 4, concentration for 50% growth inhibition: 120 nM
The estimate for compound 4 lay 100-fold (2.00 log units) above the measured number; measured number outside the range, below it.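

In this assay bromo in place of hydrogen on an aromatic carbon brought a 770-fold lower number from compound 3 to compound 4 (2.89 log units; beyond the scatter) and thus pointed the same way as on the core of compound 1, but the size of the step did not carry over from one core to the other: the same change on two cores in this assay, an 8.5-fold lower number (0.93 log units; beyond the scatter) from compound 1 to compound 2 and a 770-fold lower number (2.89 log units; beyond the scatter) from compound 3 to compound 4, 91-fold (1.96 log units) apart, beyond the scatter of two such steps. Across these two pairs, then, the direction of the change held and neither pair goes against it, whereas a step measured on one core gave no reliable measure of its size on the other. Two pairs do not establish a rule for the series, and they do not show which of the several differences between the two cores goes with the larger step, nor why the steps differ.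

The compounds shown leave open whether fluoro, nitro or an amine in place of the bromo would also lower the number. They also leave open how the step would change on a core that differs from either of these in only one place.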